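Chain length and cytotoxic read-out in a tetrabromo series

A few compounds are considered here, and "the series" means these few. Any claim that something is new, unique, unknown or untested is made for them only; others in the source may bear on it.

Measured so far:
compound 1 `Cc1nc2c(Br)c(Br)c(Br)c(Br)c2n1CCCC#N`, 65%
compound 2 `N#CCCCCn1cnc2c(Br)c(Br)c(Br)c(Br)c21`, 102%

In a functional assay on MCF7 cells (Homo sapiens) for cytotoxicity, read by MTT assay, with a stated time of 24 h, tested at 10 uM (on this read-out lower numbers stand for a stronger effect and higher numbers for a weaker effect at the one concentration tested), compound 2 gives 102%, the highest of the two numbers and thus the weaker effect; compound 1 gives 65%, a number lower by more than the scatter. The next compound, compound 3 `N#CCCCn1cnc2c(Br)c(Br)c(Br)c(Br)c21`, has not yet been measured in this assay. It differs from compound 2 in one place: cyano in place of cyanomethyl on a saturated chain carbon, three bonds along the chain from an aromatic nitrogen. Among the compounds with values here, no measured pair isolates this change, and compound 1, which shares the 3-cyanopropyl chain with compound 3, also differs from compound 2 elsewhere, so its value is only an indirect pointer. In this assay the expected step of a number 14 percentage points lower from compound 2 to compound 3 (beyond the scatter) is small, towards a lower number, and may not exceed the scatter. For compound 3 the estimate is 88%, with a range from 62% to 108%.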

Compound 3, a percentage reported as activity, at one concentration (the size of the read-out at that concentration, not a potency): 89%
For compound 3 the middle estimate is 1 percentage points below the measured one; the range from low to high includes it.
By their numbers in this assay, from the lowest: compound 1; then compound 3; then compound 2.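

In this assay, going from the 4-cyanobutyl chain to the 3-cyanopropyl chain gives a number 13 percentage points lower from compound 2 to compound 3 (beyond the scatter) as the first isolated read on chain length at this position, so this one change in chain length registers on its own. With the 3-cyanopropyl chain held constant, hydrogen in place of methyl on an aromatic carbon gives a number 24 percentage points higher from compound 1 to compound 3 (beyond the scatter) and thereby separates the effect of that substituent from chain length in this pair. Nothing available here accounts for either step.

Going by these compounds, two chain lengths define no trend, so the 2-cyanoethyl chain, a longer chain than 4-cyanobutyl, and an amine or a carboxylic acid in place of the nitrile remain open. On these data alone, whether the methyl step carries over to the 4-cyanobutyl chain also remains open.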